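The compounds below may be only part of what the source reports. "The series", "measured", "known", "first", "only" and "open" are said of these compounds alone.

In a functional assay on MGC-803 cells (Homo sapiens) for antiproliferative activity, read by MTT assay, with a stated time of 72 h (on this read-out lower numbers stand for stronger inhibition and higher numbers for weaker inhibition), compound 1 `CCCSc1nc(N/N=C/c2ccccc2Cl)c2nnn(Cc3ccccc3)c2n1` gives 10900 nM, the higher of the two numbers measured here; compound 2 `C#CCSc1nc(N/N=C/c2cc(OC)c(OC)c(OC)c2)c2nnn(Cc3ccccc3)c2n1` gives 4670 nM, a gap that lies beyond the usual scatter. Compound 3 `CCCSc1nc(N/N=C/c2ccccc2F)c2nnn(Cc3ccccc3)c2n1` has not yet been measured; it differs from compound 1 by fluoro in place of chloro on an aromatic carbon. Going by the values given here, no step between measured compounds covers this change, so the expected step of a 1.1-fold higher number from compound 1 to compound 3 (0.04 log units; within the scatter) is small, with no direction clearly beyond the scatter. Compound 3 is therefore expected in this assay to give about 12000 nM, within a range from 5000 nM to 30000 nM.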

Compound 3, half-maximal inhibitory concentration: > 64000 nM
Compound 3 ended at the assay's limit; the forecaster's own chance of this, stated with the estimate: 10%; at least 5.3-fold (0.72 log units) between middle value and limit.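

In this assay, fluoro in place of chloro on an aromatic carbon, ortho to a large group, gives an at least 5.8-fold higher number from compound 1 to compound 3 (0.76 log units; beyond the scatter). Going by these compounds alone, no earlier step covered this position, and this is the first sign that the read-out responds to the choice of halogen there, although it rests on this single pair. Compound 3 stands at a limit of the assay, not at a number: the limit of > 64000 nM in this assay, at which 1 of the 3 values shown sits.

Going by these compounds, whether bromo, methyl or a plain hydrogen at this place would read like chloro or like fluoro stays open. On these data alone, the full size of the step also stays open.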